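A few compounds are considered here, and "the series" means these few. Any claim that something is new, unique, unknown or untested is made for them only; others in the source may bear on it.

Compound 1 `C=C1C(=O)O[C@@H]2CC(C)=C([C@@H](C)CCCOC(C)=O)[C@@H](OC(=O)COc3ccc([N+](=O)[O-])cc3[N+](=O)[O-])[C@H]12` and compound 2 `C=C1C(=O)O[C@@H]2CC(C)=C([C@@H](C)CCCOC(C)=O)[C@@H](OC(=O)COc3cccc4cccnc34)[C@H]12` share one core and differ only in the aryl group of the ester. In a functional assay on HCT-116 cells (Homo sapiens) for cytotoxicity, read by sulforhodamine B assay, with a stated time of 72 h (on this read-out higher numbers stand for weaker inhibition and lower numbers for stronger inhibition), compound 1 reaches only a limit, > 100000 nM. In this assay, going by the values given here, compound 2 gives 12100 nM, the only full number among the two values recorded. The step of an at least 8.2-fold lower number from compound 1 to compound 2 (0.91 log units; beyond the scatter) cannot be sized more closely, since compound 1 sits at the limit of the limit of > 100000 nM in this assay, at which 1 of the 2 values shown sits. Compound 3 `C=C1C(=O)O[C@@H]2CC(C)=C([C@@H](C)CCCOC(C)=O)[C@@H](OC(=O)COc3ccc4c(CC)noc4c3)[C@H]12` has not yet been measured; it differs from compound 2 by a group of 11 heavy atoms (9 carbon, 1 nitrogen, 1 oxygen; one five-membered aromatic ring with 2 hetero atoms, one six-membered aromatic ring of carbon only) in place of a group of 10 heavy atoms (9 carbon, 1 nitrogen; one six-membered aromatic ring of carbon only, one six-membered aromatic ring with 1 hetero atom), on an oxygen on a saturated carbon. Among the compounds with values here, the single measured step concerns the move away from 2,4-dinitrophenyl and does not bear directly on the change in compound 3, so no guidance on direction exists. Compound 3 is therefore expected to show a step of no change at the digits printed from compound 2 to compound 3 (within the scatter) in this assay, nothing beyond the scatter. Compound 3 is estimated at 12100 nM, within 5000 nM to 30000 nM.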

Compound 3, half-maximal inhibitory concentration: 18300 nM
Estimate against measurement, compound 3: 1.5-fold (0.18 log units) below, within the range that was stated.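

In this assay, setting the new group with a five-membered aromatic ring with 2 hetero atoms in place of quinolin-8-yl, on an oxygen on a saturated carbon, gives a 1.5-fold higher number from compound 2 to compound 3 (0.18 log units; within the scatter), so these two different aromatic groups cannot be told apart at this position. The move away from 2,4-dinitrophenyl now has a second instance, with an at least 5.4-fold lower number from compound 1 to compound 3 (0.73 log units; beyond the scatter). That step cannot be sized more closely, as compound 1 is a limit of the assay: the limit of > 100000 nM in this assay, at which 1 of the 3 values shown sits.

The compounds shown leave open whether a group without an aromatic ring at this position, such as a simple amine or a longer alkyl chain, would stay level with compound 2 and compound 3. Nor do they tell whether a phenyl ring carrying a single nitro group would fall with compound 1 or with those two.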